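The source may report more compounds than this note shows. Statements on the series, on what has been measured and on what is new or still open speak of the compounds shown alone.

The measured compounds:

Compound 1, `CCOC(=O)C1=C(Nc2ccccc2)S/C(=C\c2ccc(C(=O)O)cc2)C1=O`, gives < 10% in a functional assay on MCF7 cells (Homo sapiens) for inhibition, read by MTT assay, with a stated time of 72 h, tested at 10 uM (on this read-out lower numbers stand for less inhibition and higher numbers for more inhibition at the one concentration tested (going by the name of the read-out)), which is a limit of the assay and not a number.
Compound 2, `CCOC(=O)C1=C(Nc2ccc(Br)cc2)S/C(=C\c2ccc[nH]2)C1=O`, gives < 10%, again a limit rather than a number.
Compound 3, `CCOC(=O)C1=C(Nc2cccc(F)c2)S/C(=C\c2ccc[nH]2)C1=O`, gives < 10%, again only a limit.

Compound 1 therefore stands at the limit of < 10% in this assay, at which 3 of the 3 values shown sit; its reading is no more than a ceiling, and nothing places it above or below the other two. Among the compounds with values here, the only step between measured compounds that differ in one place, a step that the two limits leave unreadable from compound 2 to compound 3, cannot be read either, and it concerns the group on the amine nitrogen, not the part that changes here.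

Compound 4, `CCOC(=O)C1=C(Nc2ccccc2)S/C(=C\c2cc3ncccc3[nH]2)C1=O`, is the compound still to be measured. It differs from compound 1 in one place: a group of 9 heavy atoms (7 carbon, 2 nitrogen; one five-membered aromatic ring with 1 hetero atom, one six-membered aromatic ring with 1 hetero atom) in place of a group of 9 heavy atoms (7 carbon, 2 oxygen; one six-membered aromatic ring of carbon only), on a double-bonded chain carbon bound to a double-bonded ring carbon. Within the data shown here, no measured step touches this position, so the size and direction of the change remain open. Among the measured compounds shown here, with every value so far at the limit, compound 4 is expected to give about 10% in this assay, within a range from 0% to 30%, meaning an expected step of a number no lower from compound 1 to compound 4 (the limit leaves the size open) that most likely stays within the scatter.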

Compound 4, a percentage reported as inhibition, at one concentration (the size of the read-out at that concentration, not a potency): 42.2%
Compound 4: middle estimate off by 32.2 percentage points, on the low side; measured number above the stated range.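

Within the data shown here, this position, on a double-bonded chain carbon bound to a double-bonded ring carbon, is the first place in the set where a change can be read: in this assay, putting the two-ring group in place of 4-carboxyphenyl gives a number at least 32.2 percentage points higher from compound 1 to compound 4 (beyond the scatter). The two groups match in heavy atoms, hydrogen-bond donors, hydrogen-bond acceptors and net charge, so these counts do not separate them, and the step goes with a difference in which atoms and rings are present. Compound 4 is the only compound shown with a reading that is a number and not a limit: the limit of < 10% in this assay, at which 3 of the 4 values shown sit.

Still open, on these data alone, is whether the step follows the loss of the carboxylic acid or the arrival of the two-ring group. A plain phenyl or a methyl ester at this place would separate the two, and the compounds shown do not say whether the five-membered or the six-membered ring of the entering group carries the step.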